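Benzoyl for phenoxy on a thiourea-linked indole series

The source may report more compounds than this note shows. Statements on the series, on what has been measured and on what is new or still open speak of the compounds shown alone.

Three thioureas were tested in an ADME assay on cells for inhibition of Amine oxidase [flavin-containing] A (Homo sapiens), read by spectrophotometry; a higher number here means a weaker inhibitor, a lower number a stronger inhibitor. Compound 1 `Oc1ccccc1NC(=S)Nc1ccc2[nH]ccc2c1` gives 39000 nM in this assay. Compound 2 `Oc1ccc(NC(=S)Nc2ccc3[nH]ccc3c2)cc1` is recorded in this assay only as "not active" (no number reported), with no number behind it. Compound 3 `S=C(Nc1ccc(Oc2ccccc2)cc1)Nc1ccc2[nH]ccc2c1` likewise stands in this assay at "not active" (no number reported), so no number places it against compound 1, and compound 2 shares the same fate. Compound 4 `O=C(c1ccccc1)c1ccc(NC(=S)Nc2ccc3[nH]ccc3c2)cc1` differs from compound 3 by benzoyl in place of phenoxy on an aromatic carbon, a benzoyl in place of phenoxy on an aromatic carbon. Among the measured compounds shown here, no step between measured compounds gives a size for such a swap, and the two neighbours offer no number to anchor it; any shift in this assay is expected to stay within the scatter, most likely leaving compound 4 without a number as well. Compound 4 is therefore estimated at 60000 nM, within 15000 nM to 250000 nM.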

Compound 4, half-maximal inhibitory concentration: "not active" (no number reported)
Nothing numeric was reported for compound 4, and the estimate cannot be compared.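

Compound 3 and compound 4 both lack a number in this assay, so no step can be read between them. Nothing shown here offers an explanation. The compounds shown leave open how benzoyl and phenoxy compare in this inhibition.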